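Ethyl to tert-butyl on the isoxazole of compound 1

A few compounds are considered here, and "the series" means these few. Any claim that something is new, unique, unknown or untested is made for them only; others in the source may bear on it.

Measured compounds in an assay on TT cells for inhibition of proto-oncogene tyrosine-protein kinase receptor Ret variant C634W (Homo sapiens), read by MTT assay, with a stated time of 10 days; on this read-out higher numbers stand for weaker inhibition of growth and lower numbers for stronger inhibition of growth:
- compound 1 `CCc1cc(-c2nn(C(C)C)c3ncnc(N)c23)no1` gives 2610 nM
- compound 2 `CC(C)n1nc(/C=N/OCc2ccccc2)c2c(N)ncnc21` gives 9270 nM
- compound 3 `CCCCCCCn1nc(-c2cc(C3CC3)on2)c2c(N)ncnc21` gives only a limit, > 10000 nM

Compound 1 has the lowest of the two numbers shown in this assay; compound 2 sits at a higher number, a gap beyond the scatter. The value for compound 3 is a limit of the assay and not a number, and it marks the limit of > 10000 nM in this assay, at which 1 of the 3 values shown sits, in this assay. Going by the values given here, no pair of measured compounds differs in one place, so no measured step is available.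

Compound 4 `CC(C)n1nc(-c2cc(C(C)(C)C)on2)c2c(N)ncnc21` is not yet measured. It differs from compound 1 by tert-butyl in place of ethyl on an aromatic carbon. Among the compounds with values here, with no measured step to rest on, the expectation for the change from compound 1 to compound 4 is a step in this assay of a 1.3-fold lower number from compound 1 to compound 4 (0.12 log units; within the scatter), that is, none beyond the scatter, with perhaps a slight lowering of the number. Compound 4 is therefore estimated at 2000 nM in this assay, within a range from 600 nM to 6500 nM.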

Compound 4, concentration for 50% growth inhibition: > 10000 nM
Compound 4 was reported as a limit (the forecaster's own chance of this, stated with the estimate: 10%); middle value at least 5.0-fold (0.69 log units) away from the limit.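

In this assay compound 4 gives > 10000 nM, which is a limit of the assay and not a number. Going by these compounds alone, this is the first measured step, and it shows that the position on an aromatic carbon next to the ring oxygen is not indifferent to its group: tert-butyl in place of ethyl gives an at least 3.8-fold higher number from compound 1 to compound 4 (0.58 log units; beyond the scatter). The full size of this step cannot be read, and the series now has a second compound at the limit: the limit of > 10000 nM in this assay, at which 2 of the 4 values shown sit.

Still open, going by these compounds, is how methyl, a methoxymethyl chain or an aminomethyl group would read at this position in this assay. The compounds shown also do not tell whether any group at this position gives a lower number than ethyl does in compound 1, or why tert-butyl gives a higher one.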